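The source may report more compounds than this note shows. Statements on the series, on what has been measured and on what is new or still open speak of the compounds shown alone.

Among the compounds with values here, in a functional assay on cells for positive allosteric modulation of metabotropic glutamate receptor 5 (Rattus norvegicus), read by calcium flux (on this read-out higher numbers stand for an effect only at larger amounts of compound and lower numbers for an effect already at smaller amounts), compound 2 (`O=C(Nc1cc(-c2ccccc2)nn1-c1ccccc1F)c1ccccc1`) gives 104 nM, which places it at the upper end of the two numbers measured so far. Its nearest neighbour, compound 1 (`Cc1ccc(C(=O)Nc2cc(-c3ccccc3)nn2-c2ccccc2)cc1`), gives 64 nM in this assay, and that gap lies within the usual scatter of repeated measurements, so the two cannot be told apart. Compound 3 (`O=C(Nc1cc(-c2ccccc2)nn1-c1cccc(Br)c1)c1ccccc1`) has not yet been measured; it differs from compound 2 in one place, (3-bromophenyl in place of 2-fluorophenyl on an aromatic nitrogen). Within the data shown here, no measured pair shows the effect of such a swap, so no step beyond the scatter is expected, and the step of a 1.2-fold lower number from compound 2 to compound 3 (0.06 log units; within the scatter) is an estimate only. Compound 3 is expected to give about 90 nM, within 25 nM to 350 nM.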

Compound 3, half-maximal effective concentration: 400 nM
Compound 3: middle estimate off by 4.4-fold (0.65 log units), on the low side; the whole stated range lies below it.
By their numbers in this assay, from the lowest: compounds 1 and 2 (each within the scatter of the next); then compound 3.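

Swapping the group on the aromatic nitrogen, with 3-bromophenyl in place of 2-fluorophenyl, gives a 3.8-fold higher number from compound 2 to compound 3 (0.59 log units; beyond the scatter), so this position can change the read-out beyond the scatter. The two groups have the same heavy-atom count and the same ring, so the difference lies in the halogen, its place on the ring, or both. Nothing available gives a reason for this step.

Still open, as far as these compounds go, is which of those two differences carries the step, and how a methoxy group or an amine on that ring would compare.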